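Replacing a Carbamate Chain End with Piperidine

This account rests on a few compounds, and the source may have more. Where it says the series, first, only, none or still open, it means among the compounds named here.

Compound 1 `Cc1cnc(C(=O)Nc2cc(F)cc3cccnc23)cn1`: 2100 nM
Compound 2 `CC(C)(C)OC(=O)NCCOc1cc(NC(=O)c2cnccn2)c2ncccc2c1`: 9500 nM
Compound 3 `Cc1cnc(C(=O)Nc2cc(OCCNC(=O)OC(C)(C)C)cc3cccnc23)cn1`: 2170 nM

In a functional assay on PANC-1 cells (Homo sapiens) for inhibition, read by MTT assay, with a stated time of 72 h (on this read-out lower numbers stand for stronger inhibition and higher numbers for weaker inhibition), compound 3 gives 2170 nM, the second highest of the three numbers; compound 1 gives 2100 nM, within the scatter of it, while compound 2 gives 9500 nM. Within the data shown here, the only measured step, a 4.4-fold lower number from compound 2 to compound 3 (0.64 log units; beyond the scatter), concerns the methyl on the shared core and not the chain. Compound 4 `Cc1cnc(C(=O)Nc2cc(OCCC3CCNCC3)cc3cccnc23)cn1` differs from compound 3 by piperidin-4-yl in place of (tert-butoxycarbonyl)amino on a saturated chain carbon, two bonds along the chain from an oxygen on an aromatic ring. Among the measured compounds shown here, no measured step bears on this change, so no direction can be read from the data. Compound 4 is therefore expected to stay near compound 3, with a 1.4-fold lower number from compound 3 to compound 4 (0.13 log units; within the scatter) as a working guess, giving an estimate of 1600 nM with a range from 500 nM to 5000 nM.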

Compound 4, half-maximal inhibitory concentration: > 10000 nM
Compound 4: a limit, no number; the forecaster's own chance of this, stated with the estimate: 5%; middle value at least 6.2-fold (0.79 log units) from the limit.
By their numbers in this assay, from the lowest: compounds 1 and 3 (each within the scatter of the next); then compound 2. At a limit, above all of these: compound 4.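

In this assay compound 4 gives no number but a limit: the limit of > 10000 nM in this assay, at which 1 of the 4 values shown sits. Fluoro in compound 1 and the carbamate chain in compound 3 had given values within the scatter of each other, so only this result shows that the group at this position can shift the read-out. The change of chain end gives an at least 4.6-fold higher number from compound 3 to compound 4 (0.66 log units; beyond the scatter), and the change from fluoro gives an at least 4.7-fold higher number from compound 1 to compound 4 (0.67 log units; beyond the scatter).

Where the true value of compound 4 lies stays open. So does whether the piperidine ring or its free nitrogen matters, which an acetyl group on that nitrogen, a plain primary amine or a longer chain could test.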